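Removing the Chloro Group from Compound 3

This account rests on a few compounds, and the source may have more. Where it says the series, first, only, none or still open, it means among the compounds named here.

Compound 1 `CC(C(=O)N1CCN(c2ccccc2)CC1)N1C(=O)CCC1=O`: 100%
Compound 2 `CCC(C(=O)N1CCN(c2cccc(F)c2)CC1)N1C(=O)CCC1=O`: 75%
Compound 3 `CCC(C(=O)N1CCN(c2ccc(Cl)cc2)CC1)N1C(=O)CCC1=O`: 0%

All three values come from a functional assay on the whole organism (strain Swiss) with Mus musculus as the target, in the maximal electroshock model, with a stated time of 0.25 h, at a dose of 300 mg/kg by the intraperitoneal route; on this read-out lower numbers stand for a weaker effect and higher numbers for a stronger effect at the one dose given. Compound 3 stands lowest of the three, with compound 2 nearest above it and compound 1 furthest above. Among the compounds with values here, the one measured step that bears on the change at hand is a number 75 percentage points lower from compound 2 to compound 3 (beyond the scatter), where 4-chlorophenyl took the place of 3-fluorophenyl on an amine nitrogen in a ring; that step was large.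

Compound 4 `CCC(C(=O)N1CCN(c2ccccc2)CC1)N1C(=O)CCC1=O` differs from compound 3 as follows: hydrogen in place of chloro on an aromatic carbon. Taking the chloro away undoes the change that brought the large drop into compound 3, and compound 1, which also carries a plain phenyl group, gives 100% in this assay. A large rise is therefore expected, a number 75 percentage points higher from compound 3 to compound 4 (beyond the scatter). For compound 4 the estimate is 75%, within a range from 25% to 100%.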

Compound 4, a percentage reported as activity, at one dose (the size of the read-out at that dose, not a potency): 75%
Compound 4: the middle estimate sits on the measured number at the digits printed; the range from low to high includes it.
By their numbers in this assay, from the lowest: compound 3; then compounds 2 and 4 (each within the scatter of the next); then compound 1.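

Hydrogen in place of chloro on this aromatic carbon gives a number 75 percentage points higher from compound 3 to compound 4 (beyond the scatter), which ties the loss of effect in this assay to the chloro at this position. Hydrogen in place of fluoro gives no change at the digits printed from compound 2 to compound 4 (within the scatter), so the 3-fluorophenyl and phenyl groups cannot be told apart here. With the phenyl kept, methyl in place of hydrogen on the chain carbon gives a number 25 percentage points lower from compound 1 to compound 4 (beyond the scatter), so the chain matters too.

Nothing here explains why the chloro has this effect. From the compounds shown here alone, whether bromo or methoxy on that same aromatic carbon behaves like chloro or like hydrogen stays open.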